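Fluorophenyl series: from fluoro to trifluoromethyl

The source may hold more compounds than are shown below. What is called first, only, known or untested is meant among the compounds shown, and "the series" means these compounds.

In an ADME assay on THP-1 cells (Homo sapiens) for cytotoxicity, read by flow cytometry and propidium iodide staining, with a stated time of 72 h (on this read-out higher numbers stand for weaker inhibition and lower numbers for stronger inhibition), compound 1 `CC(=O)Nc1ccc(O)c(C(=O)/C=C/c2ccccc2F)c1` gives > 125000 nM, which is a limit of the assay and not a number. Compound 2 `CC(=O)Nc1ccc(O)c(C(=O)/C=C/c2cccc(F)c2)c1` gives 78600 nM and compound 3 `CC(=O)Nc1ccc(O)c(C(=O)/C=C/c2ccc(F)cc2)c1` gives 68800 nM, two values within the scatter of each other. Compound 4 `CC(=O)Nc1ccc(O)c(C(=O)/C=C/c2ccc(C(F)(F)F)cc2)c1` carries trifluoromethyl in place of fluoro on an aromatic carbon. The nearest measured changes only move the fluoro group: an at least 1.5-fold lower number from compound 1 to compound 2 (0.20 log units; that floor lies within the scatter), an at least 1.8-fold lower number from compound 1 to compound 3 (0.25 log units; that floor lies within the scatter) and a 1.1-fold lower number from compound 2 to compound 3 (0.06 log units; within the scatter). None of these steps is shown beyond the scatter, so only a small change is expected in this assay, towards a lower number if any. The expected step, a 1.4-fold lower number from compound 3 to compound 4 (0.14 log units; within the scatter), is estimated to stay within the scatter. For compound 4 the estimated value is 50000 nM, with an expected range of 20000 nM to 110000 nM.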

Compound 4, half-maximal inhibitory concentration: 15500 nM
Beside the measured number, compound 4's estimate is 3.2-fold (0.51 log units) above it; the measured number lies below the stated range.
By their numbers in this assay, from the lowest: compound 4; then compounds 3 and 2 (each within the scatter of the next). At a limit, above all of these: compound 1.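

In this assay, trifluoromethyl in place of fluoro gives a 4.4-fold lower number from compound 3 to compound 4 (0.65 log units; beyond the scatter), the first step in the series shown beyond the scatter. None of the steps that only move the fluoro group is shown beyond it, so this place, on an aromatic carbon para to a large group, responds to exchanging the group itself.

On these data alone, whether a nitrile, an amine or a carboxylic acid at this place would give a similar step stays open, as does trifluoromethyl where compounds 1 and 2 carry fluoro. Compound 1 remains a limit and not a number, leaving its true distance from the other compounds unknown: the limit of > 125000 nM in this assay, at which 1 of the 4 values shown sits.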